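Swapping chloro for methyl on two related amide thiadiazoles

The compounds below may be only part of what the source reports. "The series", "measured", "known", "first", "only" and "open" are said of these compounds alone.

Four compounds share an amide joined to a thiadiazole that carries a phenyl ring; they differ in which ring bears a substituent and what that substituent is. Compound 1 `O=C(Nc1nnc(-c2ccc(Cl)cc2)s1)c1ccccc1` gives 4060 nM in a functional assay on B16-F10 cells (Mus musculus) for antiproliferative activity, read by MTT assay, with a stated time of 48 h; a higher number here means a weaker inhibitor, a lower number a stronger inhibitor. Compound 2 `Cc1ccc(-c2nnc(NC(=O)c3ccccc3)s2)cc1` gives 3520 nM in this assay. The change between them, (methyl in place of chloro on an aromatic carbon), made a step of a 1.2-fold lower number from compound 1 to compound 2 (0.06 log units; within the scatter). Compound 3 `O=C(Nc1nnc(-c2ccccc2)s1)c1ccc(Cl)cc1` is built from the same atoms as compound 1, joined differently; that difference between the two cores is not broken down here. In this assay compound 3 gives 4650 nM, and its number sits with those of compound 1 and compound 2 without any gap beyond the scatter.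

Compound 4 `Cc1ccc(C(=O)Nc2nnc(-c3ccccc3)s2)cc1` has not yet been measured. It differs from compound 3 by methyl in place of chloro on an aromatic carbon, the same change as between compound 1 and compound 2. Because that earlier change gave a 1.2-fold lower number from compound 1 to compound 2 (0.06 log units; within the scatter), the step from compound 3 to compound 4 is expected to be small, around a 1.2-fold lower number from compound 3 to compound 4 (0.07 log units; within the scatter). Compound 4 is therefore estimated to give about 4000 nM in this assay, likely between 2000 nM and 8000 nM.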

Compound 4, half-maximal inhibitory concentration: 2760 nM
For compound 4 the middle estimate is 1.4-fold (0.16 log units) above the measured one; the range from low to high includes it.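

In this assay, replacing chloro with methyl on the core of compound 3 gives a 1.7-fold lower number from compound 3 to compound 4 (0.23 log units; within the scatter). Set beside the same change on the core of compound 1, this step agrees with the earlier one, so the two cores give no sign of responding differently: the same change on two cores in this assay, a 1.2-fold lower number (0.06 log units; within the scatter) from compound 1 to compound 2 and a 1.7-fold lower number (0.23 log units; within the scatter) from compound 3 to compound 4, 1.5-fold (0.16 log units) apart, within the scatter of two such steps. Among these compounds, since each step lies within the scatter, the pair shows only that this swap left no readable mark on either core; it does not show that methyl gives a stronger inhibitor than chloro, and two cores cannot establish a rule for the wider series.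

The compounds shown leave open how activity responds when the place held by chloro or methyl carries a different kind of group, such as an amine, a carboxylic acid or a longer chain. They also leave open whether a swap between such groups would carry across the two cores as evenly as this one does.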